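The source may report more compounds than this note shows. Statements on the series, on what has been measured and on what is new or still open speak of the compounds shown alone.

Measured so far in an in vitro ADME assay on S9 fraction from liver (Rattus norvegicus, strain Wistar) for metabolic stability, read by HPLC, tested at 1 uM; a higher number here means that the compound lasts longer, a lower number that the compound disappears faster:
compound 1 `O=C(NCCCCc1ccccc1)Oc1cccc(-c2ccccc2)c1` gives 0.322 h
compound 2 `O=C(NCc1cccc2ccccc12)Oc1cccc(-c2ccccc2)c1` gives 0.78 h
compound 3 `NC(=O)c1cccc(-c2cccc(OC(=O)NCCCCc3ccccc3)c2)c1` gives 0.782 h

Compound 1 holds the lowest of the three numbers in this assay; compound 2 and compound 3 both lie beyond the scatter above it, and their two values fall within the scatter of each other. Among the measured compounds shown here, the only single-point step measured so far is a 2.4-fold higher number from compound 1 to compound 3 (0.39 log units; beyond the scatter), a change on the aromatic part of the shared core, away from the chain carried on the carbamate nitrogen.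

Compound 4 `CCCCNC(=O)Oc1cccc(-c2ccccc2)c1` differs from compound 1 on that chain instead: hydrogen in place of phenyl on a saturated chain carbon, four bonds along the chain from an amide-type nitrogen. For the measured compounds named here, no measured step bears directly on this change. The pair compound 1 / compound 2 also alters the group on the nitrogen, but in more than one place at once, so only the two values themselves can be set side by side; they show compound 2 with the higher number, and say nothing about the phenyl at the end of the chain on its own.

With no step of this kind in hand, the working expectation for compound 4 is a number near that of compound 1, with no step beyond the scatter in either direction, which is what a 1.2-fold higher number from compound 1 to compound 4 (0.09 log units; within the scatter) is meant to convey. Compound 4 is therefore estimated at 0.4 h, in a range from 0.15 h to 1 h.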

Compound 4, half-life in the liver assay: 0.03 h
Compound 4: the middle estimate sits 13-fold (1.12 log units) above what was measured, and the stated range ends above it.
By their numbers in the liver assay, from the lowest: compound 4; then compound 1; then compounds 2 and 3 (each within the scatter of the next).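

Among the compounds shown here, in the liver assay the phenyl on a saturated chain carbon, four bonds along the chain from an amide-type nitrogen, turns out to matter a great deal (an 11-fold lower number from compound 1 to compound 4 (1.03 log units; beyond the scatter)), and this is the first single-point step on the chain rather than on the aromatic part of the shared core. In a physicochemical assay for pharmacokinetics, read by HPLC, at pH 9.0 (on this read-out lower numbers stand for a shorter-lived compound and higher numbers for a longer-lived compound), compound 1 gives 0.713 h and compound 4 gives 0.715 h, so the same change leaves that read-out unmoved (a 1.0-fold higher number from compound 1 to compound 4 (0.00 log units; within the scatter)), and the large step belongs to the liver assay alone among the two assays. Nothing available accounts for the step or for this difference between the two assays.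

The compounds shown cannot separate the phenyl ring as such from the carbon count of the group that leaves, and a cyclohexyl or a pyridyl at this place, or a longer chain ending in a carboxylic acid or an amine, would speak to that. Also open, going by these compounds, is whether hydrogen in place of phenyl gives a step of similar size on the carbamoyl-bearing core of compound 3.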